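A few compounds are considered here, and "the series" means these few. Any claim that something is new, unique, unknown or untested is made for them only; others in the source may bear on it.

Of the compounds shown here, three have been measured in an assay on Sf9 cells for inhibition of protein deacetylase HDAC6 (Homo sapiens), read by fluorescence; on this read-out higher numbers stand for weaker inhibition and lower numbers for stronger inhibition. Compound 1 `Cn1c(Sc2c(F)cc(C(=O)NO)cc2F)nnc1-c1cccs1` gives 9 nM, the lowest of the three numbers. Compound 2 `Cn1c(Sc2c(F)cc(C(=O)NO)cc2F)nnc1-c1cccc(CN2CCCCCC2)c1` gives 10 nM, a number within the scatter of that of compound 1. Compound 3 `O=C(NO)c1ccc(-c2nnc(-c3ccccc3)o2)cc1`, built on a different core, gives 660 nM, far beyond the scatter from compound 1.

Compound 4 `Cn1c(Sc2c(F)cc(C(=O)NO)cc2F)nnc1-c1ncccc1F` is not yet measured. It differs from compound 1 in one place: 3-fluoropyridin-2-yl in place of thiophen-2-yl on an aromatic carbon. Among the measured compounds shown here, no measured pair differs in exactly this way, so the size of the step cannot be read off directly. What the data show is that compounds 1 and 2, which differ in the group attached to the shared core, give numbers within the scatter of each other, so this part of the structure has so far tolerated change without a shift in the read-out. On that basis the step from compound 1 to compound 4 is expected to be small, a 1.3-fold higher number from compound 1 to compound 4 (0.12 log units; within the scatter), with no clear direction and most likely none beyond the scatter. Compound 4 is estimated to give 12 nM in this assay, with a range from 5 nM to 35 nM.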

Compound 4, half-maximal inhibitory concentration: 6 nM
The estimate for compound 4 lay 2.0-fold (0.30 log units) above the measured number; low and high end bracket the measured number.
By their numbers in this assay, from the lowest: compounds 4, 1 and 2 (each within the scatter of the next); then compound 3.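

In this assay, 3-fluoropyridin-2-yl in place of thiophen-2-yl on the aromatic carbon of the shared core gives a 1.5-fold lower number from compound 1 to compound 4 (0.18 log units; within the scatter). Among the compounds shown here, this is the first step read directly at this position, and it shows that a six-membered aromatic ring carrying a ring nitrogen and a fluorine can replace the five-membered thiophene without a shift beyond the scatter. No evidence is available to explain this outcome.

Going by these compounds, the ring nitrogen and the fluorine enter together, so what each contributes alone remains open, and a plain pyridin-2-yl or a 3-fluorophenyl group would separate them. On these data alone, how far this position stays open to change is also unsettled, as a carboxylic acid or an aminomethyl group on this ring would test a quite different kind of substituent.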